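Dichlorobenzyl for ethyl on the core of compound 1

The source may report more compounds than this note shows. Statements on the series, on what has been measured and on what is new or still open speak of the compounds shown alone.

Compound 1 `CCn1c(=O)n(C2OC(CO)[C@@H](O)[C@H]2O)c2nc(N)nc(O)c21` is the reference point of this small set. Within the data shown here, in a functional assay on the whole organism (B cells) with Mus musculus as the target (a higher number here means a larger maximal response, a lower number a smaller maximal response), compound 1 gives 82%, the highest of the three numbers known. Among the measured compounds shown here, compound 2 `C=CCn1c(=O)n(C2C=CC(CO)O2)c2nc(N)nc(O)c21` gives 45% in this assay, and compound 3 `C=CCN1C(=C(C(=O)OCC)C(=O)OCC)N([C@H]2OC(CO)[C@H]3OC(C)(C)O[C@H]32)c2cc(N)nc(O)c21` gives 0% in this assay; both gaps to compound 1 lie beyond the scatter, though no single-point step connects these compounds, so the pairs show only what their two values show. The next member, compound 4 `Nc1nc(O)c2c(n1)n(C1OC(CO)[C@@H](O)[C@H]1O)c(=O)n2Cc1ccc(Cl)c(Cl)c1`, differs from compound 1 in one place: 3,4-dichlorophenyl in place of methyl on a saturated chain carbon bound to an aromatic nitrogen. For the measured compounds named here, with no comparable step measured, a moderate drop in this assay for compound 4 is expected, a number 22 percentage points lower from compound 1 to compound 4 (beyond the scatter), with wide uncertainty. The estimate for compound 4 is 60%, between 20% and 95%.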

Compound 4, largest response reached (reported as maximal response), in percent of the reference or control that the assay uses: 55%
For compound 4 the middle estimate is 5 percentage points above the measured one; measured number inside the range.
By their numbers in this assay, from the lowest: compound 3; then compounds 2 and 4 (each within the scatter of the next); then compound 1.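

In this assay, among these compounds, the change from ethyl to 3,4-dichlorobenzyl gives a number 27 percentage points lower from compound 1 to compound 4 (beyond the scatter), the first step that can be read at a single place. At this position, on a saturated chain carbon bound to an aromatic nitrogen, the response falls but is not lost: compound 4 still gives 55% in this assay. Nothing on hand accounts for the drop.

Open, going by these compounds, is whether unsubstituted benzyl, a longer chain or an amine at this place would give a different response. On these data alone, it is also open whether the step follows from the ring or from the two chlorines.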